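The source may hold more compounds than are shown below. What is called first, only, known or untested is meant among the compounds shown, and "the series" means these compounds.

Measured in a functional assay on HT-29 cells (Homo sapiens) for inhibition, read by MTT assay, with a stated time of 72 h; a higher number here means a weaker inhibitor, a lower number a stronger inhibitor:

compound 1 `COc1cc2c(Oc3ccc(NC(=O)c4nn(-c5ccccc5)c(=O)cc4C)cc3F)ccnc2cc1OCCCN1CCCCC1` gives 160 nM
compound 2 `COc1cc2c(Oc3ccc(NC(=O)c4nn(-c5ccccc5C(F)(F)F)c(=O)cc4C)cc3F)ccnc2cc1OCCCN1CCCCC1` gives 170 nM
compound 3 `COc1cc2c(Oc3ccc(NC(=O)c4nn(-c5ccccc5C(F)(F)F)c(=O)cc4C)cc3F)ccnc2cc1OCCCN1CCN(C)CC1` gives 170 nM

Compound 2 stands level with compound 3 at the digits shown, and the two share the highest number of the three; the step from compound 1 to compound 2 was a 1.1-fold higher number from compound 1 to compound 2 (0.03 log units; within the scatter), so all three numbers lie within the scatter of one another.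

Compound 4 `COc1cc2c(Oc3ccc(NC(=O)c4nn(-c5ccccc5OC(F)(F)F)c(=O)cc4C)cc3F)ccnc2cc1OCCCN1CCCCC1` is not yet measured. It differs from compound 2 in one place: trifluoromethoxy in place of trifluoromethyl on an aromatic carbon. Going by the values given here, two measured steps bear on this change. The step from compound 1 to compound 2, at the same aromatic carbon, brought in trifluoromethyl in place of hydrogen and gave a 1.1-fold higher number from compound 1 to compound 2 (0.03 log units; within the scatter). The step from compound 2 to compound 3, at a different place in the molecule, gave no change at the digits printed from compound 2 to compound 3 (within the scatter). Neither step moved the number beyond the scatter, so a change of one group to another at that aromatic carbon is expected to produce no step beyond the scatter in this assay, in either direction.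

Compound 4 is therefore expected to give 170 nM, with a range of 80 nM to 350 nM. The expected step is no change at the digits printed from compound 2 to compound 4 (within the scatter).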

Compound 4, half-maximal inhibitory concentration: 190 nM
Compound 4: the middle estimate sits 1.1-fold (0.05 log units) below what was measured; low and high end bracket the measured number.
By their numbers in this assay, from the lowest: compounds 1, 2, 3 and 4 (each within the scatter of the next).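

In this assay, the aromatic carbon ortho to a large group now has a second replacement on record, one that goes beyond adding a group to hydrogen: trifluoromethoxy in place of trifluoromethyl, which brings in one oxygen and one hydrogen-bond acceptor, gave a 1.1-fold higher number from compound 2 to compound 4 (0.05 log units; within the scatter). Measured against hydrogen at the same carbon, trifluoromethoxy gave a 1.2-fold higher number from compound 1 to compound 4 (0.07 log units; within the scatter), so hydrogen, trifluoromethyl and trifluoromethoxy in compound 1, compound 2 and compound 4 cannot be told apart by this read-out, and an added acceptor at this carbon leaves the number within the scatter. Nothing available explains this flat result at the position.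

The compounds shown leave open whether this tolerance extends to groups of another kind at this carbon, such as an amine, a carboxylic acid or a longer alkyl chain, since all three groups here carry no hydrogen-bond donor and no net charge. They also leave open whether trifluoromethoxy behaves the same way when paired with the 4-methylpiperazin-1-yl group in place of piperidin-1-yl, or when moved to another carbon of the same ring.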